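Compound 3 to compound 4: cyano for trifluoromethyl

A few compounds are considered here, and "the series" means these few. Any claim that something is new, unique, unknown or untested is made for them only; others in the source may bear on it.

In an ADME assay on BJ cells (Homo sapiens) for cytotoxicity, read by CellTiter-Glo, with a stated time of 72 h (a lower number here means that less compound is needed, a higher number that more compound is needed for the effect), compound 3 (`CC1=C2CC(C)(C)/C=C/C(=O)/C(C)=C\C3=C[C@H](C)C[C@]3(O2)[C@@]1(O)C(F)(F)F`) gives 26000 nM and stands level with compound 1 (`C[C@@H]1CC[C@H]2CC3C(=O)CC[C@@]31C2(C)C`) at 26000 nM as the highest of the three numbers. Compound 2 (`CCOC(=O)CNC(=O)[C@H](CS[C@H]1[C@@H]2C(=O)/C(C)=C\C3=C[C@H](C)C[C@@]34O[C@]2(CC1(C)C)[C@@H](C)C4=O)NC(=O)CC[C@H](N)C(=O)O`) gives 12500 nM as the furthest value from compound 3, a lower number beyond the scatter. Compound 4 (`CC1=C2CC(C)(C)/C=C/C(=O)/C(C)=C\C3=C[C@H](C)C[C@]3(O2)[C@@]1(O)C#N`) carries cyano in place of trifluoromethyl on a saturated ring carbon. Within the data shown here, no measured pair isolates this change, so the expectation rests only on the three values. A small step (a 1.5-fold lower number from compound 3 to compound 4 (0.18 log units; within the scatter)) toward a lower number is expected in this assay and would probably stay within the scatter. The estimated value for compound 4 is 17000 nM (expected range 6000 nM to 30000 nM).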

Compound 4, half-maximal effective concentration: 26000 nM
Estimate against measurement, compound 4: 1.5-fold (0.18 log units) below, within the range that was stated.
By their numbers in this assay, from the lowest: compound 2; then compounds 1, 3 and 4 (each within the scatter of the next).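

In this assay, among these compounds, cyano in place of trifluoromethyl on this saturated ring carbon gives no change at the digits printed from compound 3 to compound 4 (within the scatter), the first comparison that differs in one place. The read-out therefore does not separate these two groups at this position, although cyano brings fewer heavy atoms and a hydrogen-bond acceptor. Nothing available explains why the two groups read alike. From the compounds shown here alone, whether an amine, a carboxylic acid or a longer chain on this carbon would move the number remains open. So does whether any group here can produce a step beyond the scatter.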